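Fluoro to hydrogen on the core of compound 3

The source may hold more compounds than are shown below. What is called first, only, known or untested is meant among the compounds shown, and "the series" means these compounds.

Compound 3 `CC(C)(C)OC(=O)N1CC2CC1CC2Oc1ncnc(Nc2ccc(S(C)(=O)=O)cc2F)c1[N+](=O)[O-]` gives 86.7% in a functional assay on HEK293 cells for agonist activity at Glucose-dependent insulinotropic receptor (Homo sapiens), read by TR-FRET and cAMP accumulation, with a stated time of 60 min (on this read-out higher numbers stand for larger maximal responses and lower numbers for smaller maximal responses), the highest of the three measured values; compound 2 `CC(C)(C)OC(=O)N1CC2CC(Oc3ncnc(Nc4ccc(S(C)(=O)=O)cc4)c3[N+](=O)[O-])C1C2` stands nearest with 58.4%, and compound 1 `CC(C)(C)OC(=O)N1CC2CC(Oc3ncnc(Nc4ccc(S(C)(=O)=O)cc4F)c3[N+](=O)[O-])C1C2` stands furthest with 52.6%, both gaps beyond the scatter. Compound 4 `CC(C)(C)OC(=O)N1CC2CC1CC2Oc1ncnc(Nc2ccc(S(C)(=O)=O)cc2)c1[N+](=O)[O-]` is not yet measured. It differs from compound 3 by hydrogen in place of fluoro on an aromatic carbon. The same change has been measured once, on the shared core of compound 1 and compound 2: a number 5.8 percentage points higher from compound 1 to compound 2 (within the scatter), a step that lies within the scatter. Among the measured compounds shown here, no other measured step bears on the present question. Given a number 5.8 percentage points higher from compound 1 to compound 2 (within the scatter), no shift beyond the scatter is expected for compound 4 in this assay, in either direction; the maximal response of compound 3 should largely carry over. The estimate for compound 4 is 90%, with a range from 78% to 100%. The expected step is a number 3.3 percentage points higher from compound 3 to compound 4 (within the scatter), small and within the usual scatter.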

Compound 4, largest response reached (reported as percent of maximum), in percent of the reference or control that the assay uses: 101%
Compound 4: middle estimate off by 11 percentage points, on the low side; measured number above the stated range.
By their numbers in this assay, from the lowest: compounds 1 and 2 (each within the scatter of the next); then compound 3; then compound 4.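

Hydrogen in place of fluoro on the aromatic carbon ortho to a large group gives a number 14.3 percentage points higher from compound 3 to compound 4 (beyond the scatter) in this assay. The earlier pair left open whether this change could move the maximal response at all; this pair shows that it can do so by more than the usual scatter. Both steps point upward, but the gap between them does not support a different effect of the change on the two cores: the same change on two cores in this assay, a number 5.8 percentage points higher (within the scatter) from compound 1 to compound 2 and a number 14.3 percentage points higher (beyond the scatter) from compound 3 to compound 4, 8.5 percentage points apart, within the scatter of two such steps

With only fluoro and hydrogen shown at this position, it remains open how a chloro, methyl or methoxy group there would affect the maximal response. On these data alone, it also remains open whether the step would persist on a core carrying a free amine in place of the carbamate.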